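The source may hold more compounds than are shown below. What is called first, only, known or untested is meant among the compounds shown, and "the series" means these compounds.

Working notes on the thiourea series.

The shared core is that of compound 1 `CNC(=O)c1ccc(Oc2cccc(NC(=S)Nc3ccc(OC(F)(F)F)cc3)c2)nc1`, with the aryl group on one thiourea nitrogen as the variable part. In a functional assay on PC-3 cells (Homo sapiens) for antiproliferative activity, read by MTT assay (on this read-out higher numbers stand for weaker inhibition and lower numbers for stronger inhibition), compound 1 gives only a limit, > 100000 nM. Within the data shown here, compound 2 `CNC(=O)c1ccc(Oc2cccc(NC(=S)Nc3cccc(C(F)(F)F)c3)c2)nc1` carries 3-(trifluoromethyl)phenyl on that nitrogen; in this assay compound 2 gives 15400 nM, which is the only number obtained so far. The other value, that of compound 1, is a limit (the limit of > 100000 nM in this assay, at which 1 of the 2 values shown sits). Among the measured compounds shown here, no pair of measured compounds differs in a single place, so no measured step is available to calibrate the next change.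

Compound 3 `CNC(=O)c1ccc(Oc2cccc(NC(=S)Nc3ccc(OC)cc3)c2)nc1` is the next member. Relative to compound 2 the change is 4-methoxyphenyl in place of 3-(trifluoromethyl)phenyl on an amide-type nitrogen. Nothing measured constrains this step directly; the only neighbouring fact is that compound 1 sits at the limit while compound 2 gives a number. The step from compound 2 to compound 3 is expected to be a loss of potency beyond the usual scatter, a 2.9-fold higher number from compound 2 to compound 3 (0.47 log units; beyond the scatter), with a real chance that only a limit is returned. Compound 3 is estimated at 45000 nM, in the range 12000 nM to 150000 nM.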

Compound 3, half-maximal inhibitory concentration: > 100000 nM
Compound 3: only a limit was reported (the forecaster's own chance of this, stated with the estimate: 40%); middle value at least 2.2-fold (0.34 log units) away from the limit.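

The series now has its first readable single-place step: on the amide-type nitrogen whose other neighbour is the thiocarbonyl carbon, 4-methoxyphenyl in place of 3-(trifluoromethyl)phenyl gives an at least 6.4-fold higher number from compound 2 to compound 3 (0.81 log units; beyond the scatter). In this assay, going by these compounds, compound 3 gives only a limit, > 100000 nM, so the true size of this loss remains unknown beyond the printed minimum. The step between compound 1 and compound 3, methyl in place of trifluoromethyl on the oxygen, cannot be read, and among the three compounds only compound 2 gives a number, with the others at a shared limit: the limit of > 100000 nM in this assay, at which 2 of the 3 values shown sit.

Whether the number for compound 2 depends on the trifluoromethyl group itself or on where it sits on the ring stays open, as the compounds shown do not include 4-(trifluoromethyl)phenyl or 3-methoxyphenyl on that nitrogen. Also open, on these data alone, is how an unsubstituted phenyl, or a phenyl carrying a nitrile or an amine, would compare with 3-(trifluoromethyl)phenyl at this position.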